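Cyclohexyl Urea in Place of an Isobutyl Carbamate

The source may hold more compounds than are shown below. What is called first, only, known or untested is meant among the compounds shown, and "the series" means these compounds.

Measured compounds:
compound 1 `CC(C)COC(=O)N1CCCc2cc(S(=O)(=O)N3CC(c4ccccc4)NC3=O)ccc21`: 3720 nM
compound 2 `O=C(c1ccccc1)N1CCCc2cc(S(=O)(=O)N3CC(c4ccccc4)NC3=O)ccc21`: 19300 nM

In a functional assay on COLO 205 cells (Homo sapiens) for antiproliferative activity, read by MTT assay (on this read-out lower numbers stand for stronger inhibition and higher numbers for weaker inhibition), compound 1 stands at the lower of the two numbers shown. For the measured compounds named here, the one measured step, a 5.2-fold higher number from compound 1 to compound 2 (0.72 log units; beyond the scatter), is a modest loss and is the only comparison that bears here. Compound 3 `O=C(NC1CCCCC1)N1CCCc2cc(S(=O)(=O)N3CC(c4ccccc4)NC3=O)ccc21` differs from compound 1 at the same carbonyl carbon: cyclohexylamino in place of isobutoxy on a carbonyl carbon. The entering group keeps a single heteroatom attached to the carbonyl, as the leaving group did, so a step smaller than that seen in a 5.2-fold higher number from compound 1 to compound 2 (0.72 log units; beyond the scatter) is expected, in either direction or none beyond the scatter. Compound 3 is therefore estimated at 4500 nM, within 1500 nM to 13000 nM, an expected step of a 1.2-fold higher number from compound 1 to compound 3 (0.08 log units; within the scatter).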

Compound 3, half-maximal inhibitory concentration: 3890 nM
The estimate for compound 3 lay 1.2-fold (0.06 log units) above the measured number, within the range that was stated.
By their numbers in this assay, from the lowest: compounds 1 and 3 (each within the scatter of the next); then compound 2.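

With cyclohexylamino in place of isobutoxy, this assay gives a 1.0-fold higher number from compound 1 to compound 3 (0.02 log units; within the scatter) in this comparison, so on this carbonyl carbon a larger group with a ring and a hydrogen-bond donor matches the isobutyl carbamate. For the compounds shown here, the step of a 5.0-fold lower number from compound 2 to compound 3 (0.70 log units; beyond the scatter) sets compound 2 apart from both, which the single earlier step could only begin to show. Nothing here gives a cause for either step.

Still open, from the compounds shown here alone, is whether phenylamino on this carbonyl carbon would match compound 3 or stay nearer compound 2. An open-chain isobutylamino group would test whether the cyclohexane ring matters at all.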